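Ester to sulfonate on a shared core: cytotoxicity outlook

The compounds below may be only part of what the source reports. "The series", "measured", "known", "first", "only" and "open" are said of these compounds alone.

Compound 1, `CCCC(=O)OC1CCC(CN2CCN(c3cc(=O)c4cc(C(F)(F)F)cc([N+](=O)[O-])c4s3)CC2)CC1`, gives in an ADME assay on Vero cells (Chlorocebus sabaeus) for cytotoxicity, read by MTT assay, with a stated time of 48 h (on this read-out lower numbers stand for stronger inhibition and higher numbers for weaker inhibition), only a limit, > 64 ug/mL.
Compound 2, `O=C(OC1CCC(CN2CCN(c3cc(=O)c4cc(C(F)(F)F)cc([N+](=O)[O-])c4s3)CC2)CC1)c1ccco1`, gives in this assay only a limit, > 64 ug/mL.
Compound 3, `O=C(OC1CCC(CN2CCN(c3cc(=O)c4cc(C(F)(F)F)cc([N+](=O)[O-])c4s3)CC2)CC1)c1ccc(F)cc1`, gives in this assay only a limit, > 64 ug/mL.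

Compound 3 therefore stands where every measured compound stands: at the limit of > 64 ug/mL in this assay, at which 3 of the 3 values shown sit. Of the three measured steps, two lead to compound 3, namely a step that the two limits leave unreadable from compound 1 to compound 3 and a step that the two limits leave unreadable from compound 2 to compound 3, and the third, a step that the two limits leave unreadable from compound 1 to compound 2, is of the same kind; none of them yields a readable size, since each end is a limit.

Compound 4, `O=c1cc(N2CCN(CC3CCC(OS(=O)(=O)c4ccccc4)CC3)CC2)sc2c([N+](=O)[O-])cc(C(F)(F)F)cc12`, differs from compound 3 by phenylsulfonyl in place of (4-fluorophenyl)carbonyl on an oxygen on a saturated carbon. For the measured compounds named here, no measured step carries a readable size that bears on this change, so the only guide is that all three neighbours sit at the same limit.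

Compound 4 is therefore expected to remain at or near that limit, with the step that the limit leaves unreadable from compound 3 to compound 4 expected to stay within the scatter. The estimate for compound 4 in this assay is 80 ug/mL, ranging from 40 ug/mL to 160 ug/mL.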

Compound 4, half-maximal inhibitory concentration: > 64 ug/mL
Compound 4: a limit, no number; the forecaster's own chance of this, stated with the estimate: 80%; the middle value lies beyond the limit too.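

For the compounds shown here, compound 4, like compound 1, compound 2 and compound 3, gives only a limit in this assay, so no step to compound 4 can be read: the limit of > 64 ug/mL in this assay, at which 4 of the 4 values shown sit. The compounds shown leave open whether phenylsulfonyl in place of the carbonyl groups changes cytotoxicity at all, and at what concentration any of these four compounds would reach half-maximal inhibition.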